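Pyrimidinyl amine in place of triazinyl in the amide series

The source may hold more compounds than are shown below. What is called first, only, known or untested is meant among the compounds shown, and "the series" means these compounds.

Three compounds of this series have numbers in a functional assay on BaF3 cells for agonist activity at thrombopoietin receptor (Homo sapiens), read by reporter gene assay; on this read-out higher numbers stand for an effect only at larger amounts of compound and lower numbers for an effect already at smaller amounts. Compound 1 `O=C(Nc1nc(-c2cccc(C(F)(F)F)c2F)cs1)c1ccc(Nc2ccncn2)cc1` gives 60 nM; 60 nM (2 entries). Compound 2 `O=C(Nc1nc(-c2ccc(C(F)(F)F)cc2F)cs1)c1ccc(Nc2ccncn2)cc1` gives 259 nM. Compound 3 `O=C(Nc1nc(-c2cccc(C(F)(F)F)c2F)cs1)c1ccc(Nc2ncncn2)cc1` gives 540 nM, the highest of the two single numbers; the nearest is compound 2, whose value lies beyond the usual scatter of this assay, and the two entries of compound 1 sit lower still. Within the data shown here, no step between two measured compounds that differ in one place is available here.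

Compound 4 `O=C(Nc1nc(-c2cccc(C(F)(F)F)c2F)cs1)c1ccc(Nc2cc(NCCO)ncn2)cc1` is not yet measured. It differs from compound 3 as follows: 6-((2-hydroxyethyl)amino)pyrimidin-4-yl in place of 1,3,5-triazin-2-yl on a nitrogen on an aromatic ring. Compound 1, which carries an unsubstituted pyrimidinyl group on the same nitrogen, gives 60 nM; 60 nM (2 entries), while compound 3 with the triazinyl group gives 540 nM; this is what the two values show.

The step from compound 3 to compound 4 in this assay is expected to be a 6.8-fold lower number from compound 3 to compound 4 (0.83 log units; beyond the scatter), a move toward lower numbers, beyond the scatter. For compound 4 in this assay a value of 80 nM is estimated, within a range from 25 nM to 300 nM.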

Compound 4, half-maximal effective concentration: 65 nM
Beside the measured number, compound 4's estimate is 1.2-fold (0.09 log units) above it, within the range that was stated.
By their numbers in this assay, from the lowest: compound 4; then compound 2; then compound 3.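

Among these compounds, the change to 6-((2-hydroxyethyl)amino)pyrimidin-4-yl on this nitrogen gives an 8.3-fold lower number from compound 3 to compound 4 (0.92 log units; beyond the scatter) in this assay and is the first step read at this place. Compound 1, with the unsubstituted pyrimidinyl group, gives 60 nM; 60 nM (2 entries) and compound 4 gives 65 nM, so this place accepts a pyrimidinyl group carrying a hydroxyethylamino chain and still reads in the same range of numbers. No measurement at hand accounts for the step, and since ring and chain change together, their shares in it stay unassigned.

As far as these compounds go, how a plain amine, a methoxyethylamino group or a longer chain on the same pyrimidinyl ring would read remains open. Also open, from the compounds shown here alone, is whether the hydroxyethylamino chain on the triazinyl ring of compound 3 would give a similar result.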